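A phenoxyethyl ether on the hydroxy of compound 1

The source may report more compounds than this note shows. Statements on the series, on what has been measured and on what is new or still open speak of the compounds shown alone.

Compound 1 `COc1cc(OC)c2c(c1)C(C(O)c1ccc(O)cc1)OC2=O` carries a hydroxy group on an aromatic ring of the shared core. In an ADME assay on RAW264.7 cells (Mus musculus) for cytotoxicity, read by MTT assay, with a stated time of 24 h, in the absence of a further agent (on this read-out lower numbers stand for stronger inhibition and higher numbers for weaker inhibition), compound 1 gives > 40000 nM, which is a limit of the assay and not a number. Two ethers of that hydroxy have been measured beside it. Compound 2 `COCCCCOc1ccc(C(O)C2OC(=O)c3c(OC)cc(OC)cc32)cc1` gives > 40000 nM in this assay, again only a limit. Compound 3 `CCOCCOc1ccc(C(O)C2OC(=O)c3c(OC)cc(OC)cc32)cc1` likewise reaches only > 40000 nM, a limit. The step that the two limits leave unreadable from compound 1 to compound 2 therefore cannot be sized, and the same holds for a step that the two limits leave unreadable from compound 1 to compound 3 and for a step that the two limits leave unreadable from compound 2 to compound 3. Going by the values given here, every value so far sits at the limit of > 40000 nM in this assay, at which 3 of the 3 values shown sit.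

Compound 4 `COc1cc(OC)c2c(c1)C(C(O)c1ccc(OCCOc3ccccc3)cc1)OC2=O` is the next ether of this kind: 2-phenoxyethyl in place of hydrogen on an oxygen on an aromatic ring. The measured steps that bear on it are those from compound 1 to compound 2 and to compound 3, and both are unreadable. No step beyond the scatter has been seen in this assay for any change at this oxygen, with all three values resting at the limit of > 40000 nM in this assay, at which 3 of the 3 values shown sit. Compound 4 is therefore expected to stay at the limit as well, its step being a step that the limit leaves unreadable from compound 1 to compound 4, meaning no readable change. Compound 4 is estimated at 60000 nM, within 20000 nM to 200000 nM.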

Compound 4, half-maximal inhibitory concentration: > 40000 nM
Compound 4: no number, only a limit; the forecaster's own chance of this, stated with the estimate: 85%; the middle value is on the limit's open side.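

In this assay compound 4 gives > 40000 nM, a limit of the assay and not a number. Its steps to compound 1, compound 2 and compound 3 therefore cannot be read, and all four compounds rest at the same limit: the limit of > 40000 nM in this assay, at which 4 of the 4 values shown sit. The compounds shown leave open whether any ether on this oxygen changes the read-out at all.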